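The compounds below may be only part of what the source reports. "The series", "measured", "known", "first", "only" and "open" are said of these compounds alone.

Compounds measured in this study:
compound 1, `Fc1ccc(C(SCCNC2CCN(Cc3ccc(C(F)(F)F)cc3)CC2)c2ccc(F)cc2)cc1`, 190 nM
compound 2, `[O-][S+](CCNC1CCN(CC(O)Cc2ccccc2)CC1)C(c1ccc(F)cc1)c1ccc(F)cc1`, 91.8 nM
compound 3, `Fc1ccc(C(SCCNC2CCN(Cc3cc4ccccc4[nH]3)CC2)c2ccc(F)cc2)cc1`, 179 nM

All three were measured in an assay on membranes from striatum (strain Sprague-Dawley) for displacement of a labelled ligand from sodium-dependent dopamine transporter (Rattus norvegicus), read by scintillation counting, with a stated time of 120 min; on this read-out lower numbers stand for stronger inhibition and higher numbers for weaker inhibition. Compound 1 gives the highest number of the three: compound 3 lies nearest, within the scatter, while compound 2 gives a number that lies beyond the scatter below it. Among the compounds with values here, the only pair differing in one place is compound 1 and compound 3, where a 1.1-fold lower number from compound 1 to compound 3 (0.03 log units; within the scatter) shows that swapping the group on a saturated chain carbon bound to an amine nitrogen in a ring left the number essentially where it was. Compound 2 differs from compound 1 in more than one place, so its values show only that a different arrangement can reach a lower number.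

Compound 4, `Fc1ccc(C(SCCNC2CCN(CC3CC3)CC2)c2ccc(F)cc2)cc1`, is not yet measured in this assay . Its difference from compound 1 is this: cyclopropyl in place of 4-(trifluoromethyl)phenyl on a saturated chain carbon bound to an amine nitrogen in a ring. Within the data shown here, the step from compound 1 to compound 3 is the only measured one at that place, and it was within the scatter, but the group entering there is far smaller than either the leaving group or the one that entered in compound 3, so that step is weak evidence for the present change.

Compound 4 is therefore expected to give a somewhat higher number than compound 1, with a 1.8-fold higher number from compound 1 to compound 4 (0.27 log units; within the scatter) as the estimated step. The estimate for compound 4 in this assay is 350 nM, with a range from 120 nM to 1000 nM.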

Compound 4, inhibition constant: 407 nM
For compound 4 the middle estimate is 1.2-fold (0.07 log units) below the measured one; the measured number falls inside the stated range.
By their numbers in this assay, from the lowest: compounds 2, 3 and 1 (each within the scatter of the next, the first and the last beyond it); then compound 4.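

In this assay, the place on a saturated chain carbon bound to an amine nitrogen in a ring proves not to be indifferent to its group: cyclopropyl gives a 2.1-fold higher number from compound 1 to compound 4 (0.33 log units; beyond the scatter) and a 2.3-fold higher number from compound 3 to compound 4 (0.36 log units; beyond the scatter), both modest but beyond the scatter, whereas the swap between the two groups it replaces gave only a 1.1-fold lower number from compound 1 to compound 3 (0.03 log units; within the scatter), within the scatter. Compound 1 and compound 3 thus stand together, with compound 4 apart from both at a higher number, so the change from 4-(trifluoromethyl)benzyl to cyclopropylmethyl costs some inhibition, though not much. No measurement shown here accounts for this difference between the groups.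

Still open, as far as these compounds go, is whether the higher number goes with the smaller count of heavy atoms or with the loss of the six-membered aromatic ring, a question that a cyclohexyl group at this place would help to separate. Also open, from the compounds shown here alone, is whether a plain phenyl group, without the trifluoromethyl, would stay level with compound 1 and compound 3, and compound 2 cannot settle either point, since it differs from them in more than one place.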